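A Cyclopropyl Analogue After Three Limit Values

The compounds below may be only part of what the source reports. "The series", "measured", "known", "first", "only" and "open" are said of these compounds alone.

Compound 3 `CC1CC/C(=N\Nc2ccc(I)cc2)c2ncc(C(=O)O)c(=O)n21` is the point of departure. In a functional assay on the whole organism for inhibition, with Rattus norvegicus as the target (on this read-out lower numbers stand for an effect already at smaller amounts and higher numbers for an effect only at larger amounts of compound), compound 3 gives only a limit, > 1000 umol/kg. Compound 1 `CC1CC/C(=N\Nc2ccccc2Cl)c2ncc(C(=O)O)c(=O)n21` is likewise recorded only as a limit in this assay, > 1000 umol/kg. Compound 2 `CC1CC/C(=N\Nc2cccc(Br)c2)c2ncc(C(=O)O)c(=O)n21` also gives only a limit in this assay, > 320 umol/kg. Since the limit of > 1000 umol/kg in this assay, at which 2 of the 3 values shown sit, and the limit of > 320 umol/kg in this assay, at which 1 of the 3 values shown sits, are all that is known, a step that the two limits leave unreadable from compound 1 to compound 2, a step that the two limits leave unreadable from compound 1 to compound 3 and a step that the two limits leave unreadable from compound 2 to compound 3 have no readable size and give no direction for the next change. Compound 4 `CC1CC/C(=N\Nc2ccc(C3CC3)cc2)c2ncc(C(=O)O)c(=O)n21` differs from compound 3 by cyclopropyl in place of iodo on an aromatic carbon. With every measured value a limit, no step beyond the scatter is expected for a number no higher from compound 3 to compound 4 (the limit leaves the size open). Compound 4 is therefore estimated at 1000 umol/kg, between 300 umol/kg and 3000 umol/kg, most probably again reported only as a limit.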

Compound 4, dose for 50% inhibition: 100 umol/kg
The estimate for compound 4 lay 10-fold (1.00 log units) above the measured number, outside the stated range (below it).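

In this assay, cyclopropyl in place of iodo on this aromatic carbon gives an at least 10-fold lower number from compound 3 to compound 4 (1.00 log units; beyond the scatter). Compound 4 is the only compound shown with a number rather than a limit, so a change at this place, para to a large group, can produce a readable step. The data shown give no reason for this step.

On these data alone, whether the three-membered ring itself matters remains open. An open chain such as isopropyl, or a methoxy group or an amine at this place, could separate the ring from other replacements of iodo.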